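This account rests on a few compounds, and the source may have more. Where it says the series, first, only, none or still open, it means among the compounds named here.

Working notes on the series.

Compound 1 `Cc1nc2c3ccccc3ccc2c2nc3c(ccc4ccccc43)c(-c3cccnc3)c12` carries a pyridin-3-yl group on the shared core. In a functional assay on HeLa cells (Homo sapiens) for cytotoxicity, read by MTT assay, with a stated time of 48 h (on this read-out lower numbers stand for stronger inhibition and higher numbers for weaker inhibition), compound 1 gives 3860 nM, the lowest of the two numbers recorded so far. Among the compounds with values here, its only measured neighbour is compound 2 `Cc1ccc(-c2c3ccc4ccccc4c3nc3c2c(C)nc2c4ccccc4ccc32)cc1`, which in this assay gives 72200 nM; the step of a 19-fold higher number from compound 1 to compound 2 (1.27 log units; beyond the scatter) shows that swapping the pyridin-3-yl for 4-methylphenyl costs a great deal.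

Compound 3 `Cc1nc2c3ccccc3ccc2c2nc3c(ccc4ccccc43)c(-c3cc(O)nc4ccccc34)c12` has not yet been measured in this assay. It differs from compound 1 at the same aromatic carbon: 2-hydroxyquinolin-4-yl in place of pyridin-3-yl on an aromatic carbon. Within the data shown here, the one step that bears on this position, a 19-fold higher number from compound 1 to compound 2 (1.27 log units; beyond the scatter), was large and went toward weaker inhibition when the pyridine nitrogen was removed. The incoming 2-hydroxyquinolin-4-yl keeps a ring nitrogen and adds a hydroxy group, but it is also markedly larger, so a moderate step toward higher numbers is expected, though with wide uncertainty. For compound 3 the expected value in this assay is 8000 nM, within 2000 nM to 40000 nM, an estimated step of a 2.1-fold higher number from compound 1 to compound 3 (0.32 log units; beyond the scatter).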

Compound 3, half-maximal inhibitory concentration: 4880 nM
The estimate for compound 3 lay 1.6-fold (0.21 log units) above the measured number; low and high end bracket the measured number.
By their numbers in this assay, from the lowest: compounds 1 and 3 (each within the scatter of the next); then compound 2.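

In this assay the step of a 1.3-fold higher number from compound 1 to compound 3 (0.10 log units; within the scatter) shows that this aromatic carbon, opposite the ring nitrogen, accepts 2-hydroxyquinolin-4-yl, with its additional ring, in place of pyridin-3-yl without a change beyond the scatter. The step of a 15-fold lower number from compound 2 to compound 3 (1.17 log units; beyond the scatter) shows that a bigger group does not by itself bring the high number seen with 4-methylphenyl: among these three compounds, the two groups with a ring nitrogen read alike and the one without stands apart. No evidence at hand gives a cause for this difference.

As far as these compounds go, whether the ring nitrogen or the hydroxy group of 2-hydroxyquinolin-4-yl contributes to this reading stays open. Also open, from the compounds shown here alone, is how a non-aromatic amine such as morpholine, or a phenyl ring carrying a carboxylic acid, would read at this carbon.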